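From compound 2 to compound 3: a longer chain

The source may hold more compounds than are shown below. What is called first, only, known or untested is meant among the compounds shown, and "the series" means these compounds.

In a functional assay for inhibition, read by fluorescence and spectrophotometry, with a stated time of 30 h (on this read-out lower numbers stand for stronger inhibition and higher numbers for weaker inhibition), compound 1 `COc1ccc(-c2cc(=O)c3ccc(OCCCCCN4CCC(C)CC4)cc3o2)cc1` gives 55100 nM and compound 2 `COc1ccc(-c2cc(=O)c3ccc(OCCCCCCN4CCC(CCO)CC4)cc3o2)cc1` gives 50400 nM. Going by the values given here, these two numbers lie within the scatter of each other, so compound 2 stands level with the only other measured compound. Compound 3 `COc1ccc(-c2cc(=O)c3ccc(OCCCCCCCN4CCC(CCO)CC4)cc3o2)cc1` differs from compound 2 in one place: (4-(2-hydroxyethyl)piperidin-1-yl)methyl in place of 4-(2-hydroxyethyl)piperidin-1-yl on a saturated chain carbon, six bonds along the chain from an oxygen on an aromatic ring. In words, (4-(2-hydroxyethyl)piperidin-1-yl)methyl replaces 4-(2-hydroxyethyl)piperidin-1-yl on a saturated chain carbon, six bonds along the chain from an oxygen on an aromatic ring. Among the compounds with values here, only one measured step bears on this change: a 1.1-fold lower number from compound 1 to compound 2 (0.04 log units; within the scatter). That step also lengthens the chain, although it changes the piperidine substituent as well, and it stays within the scatter. No shift beyond the scatter is therefore expected in this assay. The expected step is a 1.1-fold lower number from compound 2 to compound 3 (0.05 log units; within the scatter). For compound 3 the estimated value is 45000 nM, with an expected range from 20000 nM to 95000 nM.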

Compound 3, half-maximal inhibitory concentration: 52700 nM
The estimate for compound 3 lay 1.2-fold (0.07 log units) below the measured number, within the range that was stated.
By their numbers in this assay, from the lowest: compounds 2, 3 and 1 (each within the scatter of the next).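

In this assay, the step that changes the chain alone, with the 4-(2-hydroxyethyl) group held fixed, stays within the scatter (a 1.0-fold higher number from compound 2 to compound 3 (0.02 log units; within the scatter)), which the earlier step could not show, since it changed the piperidine substituent as well. The wider replacement, a group of 11 heavy atoms in place of a group of 7 heavy atoms on a saturated chain carbon, five bonds along the chain from an oxygen on an aromatic ring, also stays within the scatter (a 1.0-fold lower number from compound 1 to compound 3 (0.02 log units; within the scatter)). No independent measurement offers an explanation for these results.

All three compounds share the piperidine ring and a chain of similar length, so no change shown has moved the number beyond the scatter. As far as these compounds go, whether a much shorter chain, or a morpholine or a carboxylic acid at the chain end, would do so remains open.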